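A few compounds are considered here, and "the series" means these few. Any claim that something is new, unique, unknown or untested is made for them only; others in the source may bear on it.

The measured compounds and their values are these.

Compound 1, `CCCCCN1C(=O)C/C(=C\c2cccc(C(=O)Nc3ccc(C)cc3)c2)C1=O`, in an ADME assay on NCM460 cells (Homo sapiens) for cytotoxicity, read by MTT assay, with a stated time of 72 h (a lower number here means a stronger inhibitor, a higher number a weaker inhibitor), returns only a limit, > 100000 nM.
Compound 2, `O=C(Nc1ccccc1)c1cccc(/C=C2\CC(=O)N(c3ccccc3)C2=O)c1`, in this assay likewise returns only a limit, > 100000 nM.
Compound 3, `CCc1cccc(NC(=O)c2cccc(/C=C3\CC(=O)N(Cc4ccccc4)C3=O)c2)c1`, in this assay also returns only a limit, > 100000 nM.

Compound 2 therefore stands nowhere in particular among these numbers: none of the three values is a number at all, and all of them sit at the same place, (the limit of > 100000 nM in this assay, at which 3 of the 3 values shown sit). For the measured compounds named here, no step between any two of them can be sized, and no order among compound 1, compound 2 and compound 3 can be read from these results.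

The compound still to be measured is compound 4, `Cc1cccc(NC(=O)c2cccc(/C=C3\CC(=O)N(c4ccccc4)C3=O)c2)c1`. It differs from compound 2 in one place: methyl in place of hydrogen on an aromatic carbon, so that the phenylcarbamoyl group becomes a (3-methylphenyl)carbamoyl group.

With every neighbouring value resting at the limit, nothing here points to any step in this assay beyond the scatter in either direction. Compound 4 is accordingly expected to give no readable number in this assay either, and its estimated value is 150000 nM, between 60000 nM and 400000 nM. The step this estimate implies is expected to be a step that the limit leaves unreadable from compound 2 to compound 4, essentially none.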

Compound 4, half-maximal inhibitory concentration: > 100000 nM
Compound 4 ended at the assay's limit; the forecaster's own chance of this, stated with the estimate: 90%; the middle value is on the limit's open side.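

For the compounds shown here, compound 4 returns only the limit > 100000 nM in this assay and compound 2 also rests on a limit, so no step between the two can be read: the limit of > 100000 nM in this assay, at which 4 of the 4 values shown sit. The compounds shown leave open whether methyl in place of hydrogen on an aromatic carbon makes any difference in this assay and whether any of these compounds would give a readable number there.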